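Compound 1 to compound 4: changing the sulfur substituent

A few compounds are considered here, and "the series" means these few. Any claim that something is new, unique, unknown or untested is made for them only; others in the source may bear on it.

Measured in a functional assay on PC-3 cells (Homo sapiens) for antiproliferative activity, read by MTT assay, with a stated time of 72 h (a lower number here means a stronger inhibitor, a higher number a weaker inhibitor), as follows:
compound 1 `C#CCSc1nc(Sc2ccccn2)c(C#N)c(-c2cc(OC)c(OC)c(OC)c2)n1` gives > 10000 nM
compound 2 `C#CCSc1nc(Sc2nccs2)c(C#N)c(-c2ccc(Br)cc2)n1` gives 8530 nM
compound 3 `C=CC(=O)Nc1ccccc1CN(C(=O)Nc1cccc(C(F)(F)F)c1)C1CCN(C(C)CCC)CC1` gives 25300 nM

Compound 1 stands at the limit of > 10000 nM in this assay, at which 1 of the 3 values shown sits, and so has no number. What it carries is a limit of the assay. Among the measured compounds shown here, compound 2 and compound 3 both gave numbers, but no measured pair differs in one place, so no measured step is available as a guide.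

The next compound to be measured is compound 4 `C#CCSc1nc(Sc2nc3ccccc3s2)c(C#N)c(-c2cc(OC)c(OC)c(OC)c2)n1` and it keeps the core of compound 1. The change is 1,3-benzothiazol-2-yl in place of pyridin-2-yl on a sulfur. The nearest numerical reference is compound 2 at 8530 nM and this suggests that a value of similar size in this assay is a reasonable expectation. A large gain is not expected from this evidence, and compound 4 may also return only a limit.

The estimated step of an at least 1.1-fold lower number from compound 1 to compound 4 (0.04 log units; that floor lies within the scatter) is expected to be small, slightly toward a stronger inhibitor or within the scatter. The expected value for compound 4 is 9000 nM with 2000 nM to 30000 nM as the estimated range.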

Compound 4, half-maximal inhibitory concentration: > 20000 nM
Compound 4: a limit, no number; the forecaster's own chance of this, stated with the estimate: 45%; middle value at least 2.2-fold (0.34 log units) from the limit.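

In this assay compound 4 gives > 20000 nM, a limit of the assay and not a number. Among the compounds shown here, compound 1 also carries only a limit, so no step from compound 1 to compound 4 can be read. The compounds shown leave open whether 1,3-benzothiazol-2-yl in place of pyridin-2-yl on a sulfur changes the read-out at all, and in which direction.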